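Propylcarbamoyl in place of tert-butylcarbonyl: outlook for compound 4

The source may report more compounds than this note shows. Statements on the series, on what has been measured and on what is new or still open speak of the compounds shown alone.

Measured so far in a functional assay on MCF7 cells (Homo sapiens) for antiproliferative activity, read by sulforhodamine B assay, with a stated time of 48 h; on this read-out higher numbers stand for weaker inhibition and lower numbers for stronger inhibition:
- compound 1, `CC(C)C(=O)Nc1cccc(S(=O)(=O)Oc2ccccc2C(C)C)c1`: compound 1 gives 13000 nM
- compound 2, `CC(C)c1ccccc1OS(=O)(=O)c1ccc(NC(=O)C(C)(C)C)cc1`: compound 2 gives 6500 nM
- compound 3, `CC(C)(C)C(=O)Nc1ccc(S(=O)(=O)Oc2ccccc2I)cc1`: compound 3 gives 6600 nM

Compound 3 stands second highest of the three numbers. Its nearest neighbour is compound 2, with a 1.0-fold higher number from compound 2 to compound 3 (0.01 log units; within the scatter), and the gap from compound 1 to compound 3 also lies within the scatter, so on these values the three compounds are not separated.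

Compound 4 is `CCCNC(=O)Nc1ccc(S(=O)(=O)Oc2ccccc2I)cc1`. Relative to compound 3 the change is propylamino in place of tert-butyl on a carbonyl carbon. Among the measured compounds shown here, none of the measured steps bears on this change: the only step in hand, a 1.0-fold higher number from compound 2 to compound 3 (0.01 log units; within the scatter), concerns an aromatic carbon on the other side of the molecule and says nothing about the carbonyl substituent. For the measured compounds named here, with no step in hand for this position, the working expectation is no movement beyond the scatter, and the estimated step is a 1.2-fold higher number from compound 3 to compound 4 (0.08 log units; within the scatter). Compound 4 is therefore expected at about 8000 nM, with a range from 3000 nM to 25000 nM.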

Compound 4, half-maximal inhibitory concentration: 2900 nM
Beside the measured number, compound 4's estimate is 2.8-fold (0.44 log units) above it, outside the stated range (below it).
By their numbers in this assay, from the lowest: compound 4; then compounds 2, 3 and 1 (each within the scatter of the next).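

Of the two steps in hand, this is the only one beyond the scatter, which makes the carbonyl substituent the first position in the series seen to move the number: in this assay the change gives a 2.3-fold lower number from compound 3 to compound 4 (0.36 log units; beyond the scatter) for propylamino in place of tert-butyl on a carbonyl carbon. The heavy-atom count stays the same, while a nitrogen and a hydrogen-bond donor enter, turning ((tert-butyl)carbonyl)amino into (propylcarbamoyl)amino. No available evidence accounts for this step.

The compounds shown do not separate the part played by the entering nitrogen from that of the propyl chain; ethylamino, butylamino or dimethylamino on the same carbonyl carbon would bear on this. Going by these compounds, whether the step holds with isopropyl in place of iodo on the aromatic carbon also remains open.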